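The compounds below may be only part of what the source reports. "The series", "measured", "known", "first", "only" and "open" are said of these compounds alone.

Compound 1 `Cc1cc(OCC(=O)O)cc2cc(C)n(Cc3ccc(O)c(C(C)C)c3)c12` and compound 2 `Cc1cc2cc(OCC(=O)O)cc(Cl)c2n1Cc1ccc(O)c(C(C)C)c1` share one core and were both tested in an assay on HeLa cells for displacement of a labelled ligand from thyroid hormone receptor beta (Homo sapiens); on this read-out higher numbers stand for weaker inhibition and lower numbers for stronger inhibition. In this assay compound 1 gives 0.14 nM, and compound 2 gives 0.04 nM. Among the measured compounds shown here, the single change between them, (chloro in place of methyl on an aromatic carbon), brought a 3.5-fold lower number from compound 1 to compound 2 (0.54 log units; beyond the scatter). Compound 3 `Cc1cn(Cc2ccc(O)c(C(C)C)c2)c2c(C)cc(OCC(=O)O)cc12` is built from the same atoms as compound 1 joined differently; how the two cores differ is not broken down here. In this assay compound 3 gives 0.18 nM, a number that sits within the usual scatter of the number for compound 1, while the number for compound 2 lies beyond that scatter from it. Compound 4 `Cc1cn(Cc2ccc(O)c(C(C)C)c2)c2c(Cl)cc(OCC(=O)O)cc12` has not yet been measured. It arises from compound 3 by chloro in place of methyl on an aromatic carbon, the same change seen from compound 1 to compound 2, at a place described in the same words. For the measured compounds named here, for compound 4 the expected step is a 3.3-fold lower number from compound 3 to compound 4 (0.51 log units; beyond the scatter), set beside the earlier 3.5-fold lower number from compound 1 to compound 2 (0.54 log units; beyond the scatter) as its only measured precedent. Compound 4 is accordingly estimated at 0.055 nM, with a likely span from 0.02 nM to 0.14 nM.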

Compound 4, inhibition constant: 0.09 nM
Beside the measured number, compound 4's estimate is 1.6-fold (0.21 log units) below it; the range from low to high includes it.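

In this assay, chloro in place of methyl on an aromatic carbon of the core of compound 3 brought a 2.0-fold lower number from compound 3 to compound 4 (0.30 log units; within the scatter), so this step alone cannot be separated from the usual scatter. Set beside the earlier step on the core of compound 1, it does not differ in size: the same change on two cores in this assay, a 3.5-fold lower number (0.54 log units; beyond the scatter) from compound 1 to compound 2 and a 2.0-fold lower number (0.30 log units; within the scatter) from compound 3 to compound 4, 1.8-fold (0.24 log units) apart, within the scatter of two such steps. Across these two cores, then, the change carried over with no measurable difference in size, but this rests on one pair per core and does not show that the change would carry to any other core in this series.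

The compounds shown leave open how a fluoro, a bromo or a methoxy group would compare with chloro and methyl on this same aromatic carbon. They also leave open whether the two steps would stay alike if a longer chain ending in a carboxylic acid took the place of the carboxymethoxy group.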